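The source may report more compounds than this note shows. Statements on the series, on what has been measured and on what is new or still open speak of the compounds shown alone.

Compound 1 `CC(C(=O)NCc1ccc(C(F)(F)F)nc1Nc1ccccc1)c1ccc(NS(C)(=O)=O)c(F)c1` — in a functional assay on CHO-K1 cells for antagonist activity at transient receptor potential cation channel subfamily V member 1 (Homo sapiens), read by FLIPR (a lower number here means a stronger inhibitor, a higher number a weaker inhibitor), compound 1 gives 1400 nM.
Compound 2 `Cc1ccc(Cl)cc1Nc1nc(C(F)(F)F)ccc1CNC(=O)C(C)c1ccc(NS(C)(=O)=O)c(F)c1` — in this assay compound 2 gives 140 nM.
Compound 3 `CCCCN(C)c1nc(C(F)(F)F)ccc1CNC(=O)C(C)c1ccc(NS(C)(=O)=O)c(F)c1` — in this assay compound 3 gives 21.3 nM.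

Compound 3 holds the lowest number of the three, ahead of compound 2 by a 6.6-fold lower number from compound 2 to compound 3 (0.82 log units; beyond the scatter) and of compound 1 by a 66-fold lower number from compound 1 to compound 3 (1.82 log units; beyond the scatter). Compound 4 `CC(C(=O)NCc1ccc(C(F)(F)F)nc1N1CCC(C)(C)CC1)c1ccc(NS(C)(=O)=O)c(F)c1` keeps the whole of compound 3 except one change: 4,4-dimethylpiperidin-1-yl in place of butyl(methyl)amino on an aromatic carbon. The two steps that bear on this place, a 66-fold lower number from compound 1 to compound 3 (1.82 log units; beyond the scatter) and a 6.6-fold lower number from compound 2 to compound 3 (0.82 log units; beyond the scatter), both trade an aryl-bearing nitrogen for the butyl(methyl)amino group; compound 4 keeps a nitrogen carrying only saturated carbon, so those gains are retained rather than repeated. In this assay compound 4 is therefore expected to show no step beyond the scatter, a 1.2-fold higher number from compound 3 to compound 4 (0.07 log units; within the scatter). The estimate for compound 4 is 25 nM, with a range from 8 nM to 80 nM.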

Compound 4, half-maximal inhibitory concentration: 8 nM
For compound 4 the middle estimate is 3.1-fold (0.49 log units) above the measured one; the measured number falls inside the stated range.
By their numbers in this assay, from the lowest: compound 4; then compound 3; then compound 2; then compound 1.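

At this position, on an aromatic carbon next to the ring nitrogen, the saturated groups in this assay are not interchangeable: the ring of 4,4-dimethylpiperidin-1-yl gives a step beyond the scatter over the open butyl(methyl)amino (a 2.7-fold lower number from compound 3 to compound 4 (0.43 log units; beyond the scatter)). The gap to the aryl-bearing nitrogens also widens, with an 18-fold lower number from compound 2 to compound 4 (1.24 log units; beyond the scatter) and a 180-fold lower number from compound 1 to compound 4 (2.24 log units; beyond the scatter). Nothing at hand explains these steps. On these data alone, it remains open whether the ring or its two methyl groups carry the gain. As far as these compounds go, how piperidin-1-yl without those methyl groups, or morpholin-4-yl, would read here also stays unknown.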